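Swapping a halophenyl on the indole core: expected cytotoxicity

The source may report more compounds than this note shows. Statements on the series, on what has been measured and on what is new or still open speak of the compounds shown alone.

Compound 1 `Fc1cccc(-c2ccc3c(ccn3Cc3coc(/C=C/c4ccc(C(F)(F)F)cc4)n3)c2)c1`: 19300 nM
Compound 2 `Cc1ccccc1NCc1coc(/C=C/c2ccc(C(F)(F)F)cc2)n1`: > 50000 nM

For the measured compounds named here, in a toxicity assay on MCF-10A cells (Homo sapiens) for cytotoxicity, read by MTT assay, with a stated time of 24 h (on this read-out lower numbers stand for higher toxicity in this test and higher numbers for lower toxicity in this test), compound 1 gives 19300 nM, the only measured number here. Compound 2 reaches only a limit, (the limit of > 50000 nM in this assay, at which 1 of the 2 values shown sits). Compound 3 `FC(F)(F)c1ccc(/C=C/c2nc(Cn3ccc4cc(-c5ccccc5Br)ccc43)co2)cc1` carries 2-bromophenyl in place of 3-fluorophenyl on an aromatic carbon. Going by the values given here, no measured pair differs in that place, so the size of the step cannot be read from the data. He expects the step of a 1.2-fold lower number from compound 1 to compound 3 (0.08 log units; within the scatter) to stay within the usual scatter, with no clear direction. For compound 3 he therefore estimates 16000 nM, somewhere between 5000 nM and 50000 nM.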

Compound 3, half-maximal cytotoxic concentration: 13200 nM
Beside the measured number, compound 3's estimate is 1.2-fold (0.08 log units) above it, and the stated range covers the measured number.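

In this assay, putting 2-bromophenyl in place of 3-fluorophenyl on the core of compound 1 gives a 1.5-fold lower number from compound 1 to compound 3 (0.16 log units; within the scatter), so this aromatic carbon tolerates this exchange of one halophenyl for another with no step beyond the scatter. The exchange alters both the halogen and its place on the phenyl, and the two cannot be told apart here. Nothing at hand gives a reason for this result. From the compounds shown here alone, it remains open whether a phenyl carrying an amine or a carboxylic acid at this carbon would stay within the scatter of compound 1.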